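The compounds below may be only part of what the source reports. "The series", "measured", "known", "first", "only" and "open" are said of these compounds alone.

Measured so far:
- compound 1, `Cc1ccc(S(=O)(=O)N[C@H]2CCN(CCCOc3ccc(C(=O)C4CC4)cc3)C2)cc1`: 380 nM in an assay on isolated protein for binding affinity to histamine H2 receptor (Homo sapiens); on this read-out higher numbers stand for weaker inhibition and lower numbers for stronger inhibition
- compound 2, `CC(=O)c1ccc(OCCCN2CC[C@H](NC(=O)c3ccc(C#N)cc3)C2)cc1`: 6100 nM
- compound 3, `COc1ccc(S(=O)(=O)N[C@H]2CCN(CCCOc3ccc(C(=O)C4CC4)cc3)C2)cc1`: 1000 nM

Compound 3 holds the second highest of the three numbers in this assay; compound 1 is its nearest neighbour and compound 2 its furthest, the two sitting on either side of it. For the measured compounds named here, the only single-point step recorded in the set, a 2.6-fold higher number from compound 1 to compound 3 (0.42 log units; beyond the scatter), shows the methoxy-bearing ring giving a modestly higher number than its methyl counterpart.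

Compound 4, `O=C(c1ccc(OCCCN2CC[C@H](NS(=O)(=O)c3cccc(Cl)c3)C2)cc1)C1CC1`, is not yet measured. It differs from compound 3 by 3-chlorophenyl in place of 4-methoxyphenyl on a sulfonyl sulfur. The step from compound 1 to compound 3 is the only one that bears on this change, and only in part: it concerns a substituent swap on the same ring, not a chlorine in place of the methoxy. Compound 1, at 380 nM, lacks the methoxy and sits lower, so a modest downward move or no step beyond the scatter is expected from compound 3 to compound 4, a 2.0-fold lower number from compound 3 to compound 4 (0.30 log units; within the scatter). Compound 4 is therefore estimated at about 500 nM in this assay, within 200 nM to 1500 nM.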

Compound 4, inhibition constant: 700 nM
Beside the measured number, compound 4's estimate is 1.4-fold (0.15 log units) below it; low and high end bracket the measured number.
By their numbers in this assay, from the lowest: compounds 1, 4 and 3 (each within the scatter of the next, the first and the last beyond it); then compound 2.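

In this assay, 3-chlorophenyl on the sulfonyl sulfur gives a 1.4-fold lower number from compound 3 to compound 4 (0.15 log units; within the scatter) and a 1.8-fold higher number from compound 1 to compound 4 (0.27 log units; within the scatter), so this group cannot be told apart from either 4-methoxyphenyl or 4-methylphenyl. The earlier step, a 2.6-fold higher number from compound 1 to compound 3 (0.42 log units; beyond the scatter), did separate those two groups, and only compound 4 shows that an aryl group with a chlorine and a different substitution pattern also fits the series at this position. No measurement here explains these numbers.

The chlorine and its place on the ring change together in compound 4, so the contribution of each remains unresolved. Also open, as far as these compounds go, is how the numbers respond to an unsubstituted phenyl, a pyridine ring or a cyclohexyl group on the sulfonyl sulfur.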